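Swapping a Biaryl Arm for a Styryl Arm

This account rests on a few compounds, and the source may have more. Where it says the series, first, only, none or still open, it means among the compounds named here.

Compound 1 `CCCCCCCCS(=O)(=O)Nc1cc(-c2cccc(Cl)c2)ccc1C(=O)O` and compound 2 `CCCCCCCCS(=O)(=O)Nc1ccc(-c2ccc(OC)cc2)cc1C(=O)O` were both tested in an assay on mitochondria (strain BALB/c) for inhibition of glycerol-3-phosphate acyltransferase 1, mitochondrial (Mus musculus), read by scintillation counting, with a stated time of 10 min; on this read-out higher numbers stand for weaker inhibition and lower numbers for stronger inhibition. In this assay compound 1 gives 13800 nM, while compound 2 gives 19500 nM; the two figures lie within the scatter of each other, so compound 1 is not set apart from compound 2 by these numbers. Compound 3 `CCCCCCCCS(=O)(=O)Nc1cc(/C=C/c2ccccc2)ccc1C(=O)O` has not been measured. It differs from compound 1 in one place: 2-phenylethenyl in place of 3-chlorophenyl on an aromatic carbon. For the measured compounds named here, no measured pair shows such a change, so no step beyond the scatter is expected in either direction. Compound 3 is expected to give 12000 nM (range 4000 nM to 40000 nM), a step of a 1.2-fold lower number from compound 1 to compound 3 (0.06 log units; within the scatter) that is expected to stay within the scatter.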

Compound 3, half-maximal inhibitory concentration: 38000 nM
For compound 3 the middle estimate is 3.2-fold (0.50 log units) below the measured one; measured number inside the range.
By their numbers in this assay, from the lowest: compounds 1, 2 and 3 (each within the scatter of the next, the first and the last beyond it).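

In this assay, 2-phenylethenyl in place of 3-chlorophenyl, para to the carboxy group, gives a 2.8-fold higher number from compound 1 to compound 3 (0.44 log units; beyond the scatter) and so shows that the number at this position responds to a change of arm. The entering arm has a double bond outside the aromatic rings and no chlorine, so this one step cannot separate those two differences. Nothing measured here accounts for the step.

The compounds shown leave open which difference carries the step. They also leave open how a plain phenyl or a 2-(3-chlorophenyl)ethenyl group would stand at this position.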